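This account rests on a few compounds, and the source may have more. Where it says the series, first, only, none or still open, it means among the compounds named here.

Of the compounds shown here, three built on one shared core have been tested for how strongly they damage human kidney-derived cells. Compound 2 `COc1ccc(-c2cn3cc(C4=CCN(C(=O)c5ccccc5C(F)(F)F)CC4)ccc3n2)cc1OC` carries a (2-(trifluoromethyl)phenyl)carbonyl group on the ring nitrogen; in an ADME assay on HEK293 cells (Homo sapiens) for cytotoxicity, read by MTT assay, with a stated time of 48 h (on this read-out higher numbers stand for weaker inhibition and lower numbers for stronger inhibition), compound 2 gives 82900 nM. Compound 3 `COc1ccc(-c2cn3cc(C4=CCN(C(=O)C5CC5)CC4)ccc3n2)cc1OC` gives 77600 nM, and the step of a 1.1-fold lower number from compound 2 to compound 3 (0.03 log units; within the scatter) is too small to count. Compound 1 `COc1ccc(-c2cn3cc(C4=CCN(S(=O)(=O)CCc5ccccc5)CC4)ccc3n2)cc1OC` gives 70300 nM, with the steps of a 1.2-fold higher number from compound 1 to compound 2 (0.07 log units; within the scatter) and a 1.1-fold higher number from compound 1 to compound 3 (0.04 log units; within the scatter) likewise too small to count. On these numbers compound 2 cannot be set apart from the other two: all three sit within the usual scatter of one another, so swapping the group on the ring nitrogen, whether a sulfonyl or a carbonyl type and whatever sits on it, has left the cytotoxicity read-out essentially unchanged.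

Compound 4 `COc1ccc(-c2cn3cc(C4=CCN(C(=O)c5cccs5)CC4)ccc3n2)cc1OC` has not yet been measured. It differs from compound 2 in one place: thiophen-2-yl in place of 2-(trifluoromethyl)phenyl on a carbonyl carbon. For the measured compounds named here, the step from compound 2 to compound 3 is the closest precedent, since it also swaps the group on the carbonyl carbon, and it was within the scatter. From that, no shift beyond the scatter is expected; the expected step is a 1.0-fold lower number from compound 2 to compound 4 (0.02 log units; within the scatter). The estimate for compound 4 is 80000 nM, with a range from 40000 nM to 160000 nM.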

Compound 4, half-maximal inhibitory concentration: 98100 nM
Compound 4: middle estimate off by 1.2-fold (0.09 log units), on the low side; the range from low to high includes it.
By their numbers in this assay, from the lowest: compounds 1, 3, 2 and 4 (each within the scatter of the next).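

Thiophen-2-yl on the carbonyl carbon, a five-membered aromatic ring with one hetero atom, gives a 1.2-fold higher number from compound 2 to compound 4 (0.07 log units; within the scatter) in this assay, so a sulfur-containing ring at this place also leaves the read-out within the scatter of the six-membered carbon ring it replaces. The comparison with a small carbon ring on the same carbonyl carbon, a 1.3-fold higher number from compound 3 to compound 4 (0.10 log units; within the scatter), and the comparison with the sulfonyl group on the ring nitrogen, a 1.4-fold higher number from compound 1 to compound 4 (0.14 log units; within the scatter), are also within the scatter, so all four groups tested at this position now fall in one band with no order among them. No measurement here accounts for this lack of change.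

The compounds shown leave open whether a group of a different kind on the carbonyl carbon, such as an amine, a carboxylic acid or a longer chain, would move the cell-damage read-out beyond the scatter. They also leave open whether changes elsewhere on the shared core, rather than on the ring nitrogen, would shift the number.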